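Compound 2 to compound 4: replacing the 2-fluorophenyl group

The source may hold more compounds than are shown below. What is called first, only, known or untested is meant among the compounds shown, and "the series" means these compounds.

Measured in an ADME assay on liver for metabolic stability, with Liver microsome (Homo sapiens) as the target, read by LC-MS, using microsomes; a higher number here means faster removal of the compound, a lower number slower removal:
- compound 1 `CC(C)(C)OC[C@@H](O)C(=O)N1[C@H](C(=O)NCc2cc(Cl)ccc2-n2cnnn2)C[C@@H]2C[C@@H]21`: 21 mL.min-1.g-1
- compound 2 `O=C(NCc1cc(Cl)ccc1-n1cnnn1)[C@@H]1CC=NN1C(=O)[C@H](O)c1ccccc1F`: 16 mL.min-1.g-1
- compound 3 `CC(C)(C)[C@@H](O)C(=O)N1C[C@H]2C[C@H]2[C@H]1C(=O)NCc1cc(Cl)ccc1-n1cnnn1`: 22 mL.min-1.g-1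

The values of compound 2 and compound 1 lie within the scatter of each other, as do those of compound 2 and compound 3. On these numbers, compound 2 cannot be separated from either.

Compound 4 `COC(C)(C)[C@@H](O)C(=O)N1N=CC[C@H]1C(=O)NCc1cc(Cl)ccc1-n1cnnn1` is the next to be read. It carries 1-methoxy-1-methylethyl in place of 2-fluorophenyl on a saturated chain carbon bound to a carbonyl carbon and an oxygen on a saturated carbon

Among the measured compounds shown here, no measured pair isolates a single change, so the effect of this one has not been seen directly. Compound 1 at 21 mL.min-1.g-1 and compound 3 at 22 mL.min-1.g-1 differ structurally from compound 2, yet remain within the scatter of it. On that basis, no step beyond the scatter is expected in this assay, and neither direction is favoured. The estimated step of a 1.1-fold higher number from compound 2 to compound 4 (0.03 log units; within the scatter) is accordingly small. For compound 4 the expected value is 17 mL.min-1.g-1, with an estimated range of 10 mL.min-1.g-1 to 29 mL.min-1.g-1.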

Compound 4, intrinsic clearance in microsomes: < 12 mL.min-1.g-1
Compound 4 ended at the assay's limit (the forecaster's own chance of this, stated with the estimate: 2%); middle value at least 1.4-fold (0.15 log units) away from the limit.
By their numbers in this assay, from the lowest: compounds 2, 1 and 3 (each within the scatter of the next). At a limit, below all of these: compound 4.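

In this assay compound 4 gives < 12 mL.min-1.g-1, which is a limit of the assay and not a number. Among the compounds shown here, this is the first comparison that changes only one place, and 1-methoxy-1-methylethyl in place of 2-fluorophenyl gives an at least 1.3-fold lower number from compound 2 to compound 4 (0.12 log units; that floor lies within the scatter), so at this position the number does not depend on keeping the six-membered aromatic ring. The step is only a floor, and its true size cannot be read: the limit of < 12 mL.min-1.g-1 in this assay, at which 1 of the 4 values shown sits.

Open, from the compounds shown here alone, is how an amine, a carboxylic acid or a longer chain at this position would read in this assay. Also open, going by these compounds, is whether the same replacement would read alike on the core of compound 1 or the core of compound 3.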